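Methoxy in Place of Ethyl on a Second Core

The source may report more compounds than this note shows. Statements on the series, on what has been measured and on what is new or still open speak of the compounds shown alone.

Compound 1 `COc1ccc(S(=O)(=O)NC(=O)Nc2ccc(Cl)cc2)s1` gives 93% in a functional assay on the whole organism (6C3HED cells, Mus musculus) for inhibition, at a dose of 150 mg/kg by the oral route; a lower number here means less inhibition, a higher number more inhibition at the dose given (going by the name of the read-out).
Compound 2 `CCc1ccc(S(=O)(=O)NC(=O)Nc2ccc(Cl)cc2)s1` gives 57%.
Compound 3 `CCc1csc(S(=O)(=O)NC(=O)Nc2ccc(Cl)cc2)c1` gives 55%.

Compound 4 `COc1csc(S(=O)(=O)NC(=O)Nc2ccc(Cl)cc2)c1` is not yet measured. It differs from compound 3 by methoxy in place of ethyl on an aromatic carbon. The same kind of change, (methoxy in place of ethyl on an aromatic carbon), gave a number 36 percentage points higher from compound 2 to compound 1 (beyond the scatter). The two places are not the same word for word: in compound 1 the methoxy stands next to the ring sulfur, in compound 4 two ring bonds from the ring sulfur. The cores of compound 2 and compound 3 differ by a group of 7 heavy atoms (6 carbon, 1 sulfur; one five-membered aromatic ring with 1 hetero atom) in place of a group of 7 heavy atoms (6 carbon, 1 sulfur; one five-membered aromatic ring with 1 hetero atom), on a sulfonyl sulfur, with a number 2 percentage points lower from compound 2 to compound 3 (within the scatter), while a number 38 percentage points lower from compound 1 to compound 3 (beyond the scatter).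

The step from compound 3 to compound 4 is expected to be a number 23 percentage points higher from compound 3 to compound 4 (beyond the scatter), smaller than the earlier one because a number 36 percentage points higher from compound 2 to compound 1 (beyond the scatter) was made at a different place on the ring. Compound 4 is therefore estimated at 78%, between 58% and 96%.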

Compound 4, a percentage reported as inhibition, in the whole organism at one dose (the size of the read-out at that dose, not a potency): 36%
Beside the measured number, compound 4's estimate is 42 percentage points above it, outside the stated range (below it).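

In this assay, methoxy in place of ethyl did not carry over from one core to the other: the same change on two cores in this assay, a number 36 percentage points higher (beyond the scatter) from compound 2 to compound 1 and a number 19 percentage points lower (beyond the scatter) from compound 3 to compound 4, 55 percentage points apart, beyond the scatter of two such steps. On the core of compound 3 the change gave a number 19 percentage points lower from compound 3 to compound 4 (beyond the scatter), while 4-methoxythiophen-2-yl in place of 5-ethylthiophen-2-yl gave a number 21 percentage points lower from compound 2 to compound 4 (beyond the scatter), and 4-methoxythiophen-2-yl in place of 5-methoxythiophen-2-yl gave a number 57 percentage points lower from compound 1 to compound 4 (beyond the scatter). This shows that the step on one core did not foretell the step on the other, but two pairs give no general rule and do not show what lies behind the difference.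

The compounds shown leave open how a longer chain such as propyl, or an amine, would behave two ring bonds from the ring sulfur. They also leave open whether the two opposite steps would hold at another dose.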